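Methylsulfonylmethyl for thiocyanate on a nucleoside core

The compounds below may be only part of what the source reports. "The series", "measured", "known", "first", "only" and "open" are said of these compounds alone.

The set holds three measured compounds and one awaiting measurement. Compound 1 `O=C(/C=C/c1cc(=O)[nH]c(=O)n1COCCO)c1ccccc1` is an open-chain analogue, compound 2 `N#CSc1cn([C@H]2C[C@H](O)[C@@H](CO)O2)c(=O)[nH]c1=O` carries a cyanosulfanyl group on its shared core, and compound 3 `Nc1ncnc2c1nnn2[C@@H]1C[C@H](CO)[C@@H](CO)[C@H]1CO` is a carbocyclic structure. In an ADME assay on L1210/0 cells (Mus musculus) for cytotoxicity, with a stated time of 48 h (on this read-out higher numbers stand for weaker inhibition and lower numbers for stronger inhibition), compound 1 gives 43300 nM and compound 2 gives 78900 nM, two numbers that lie within the scatter of each other, so no order between them is claimed. Compound 3 gives only a limit in this assay, > 200000 nM, which is the limit of > 200000 nM in this assay, at which 1 of the 3 values shown sits. Thus compound 2 stands alongside compound 1 among the two numbers that are known, with compound 3 left at a limit.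

Compound 4 `CS(=O)(=O)Cc1cn([C@H]2C[C@H](O)[C@@H](CO)O2)c(=O)[nH]c1=O` differs from compound 2 in one place: (methylsulfonyl)methyl in place of cyanosulfanyl on an aromatic carbon. Going by the values given here, no measured pair in this set shares this kind of change, so there is no directly comparable step to draw on. Both compound 1 and compound 2 sit at weak inhibition in this assay, and the change exchanges one small neutral group for another on the same aromatic carbon. The step from compound 2 to compound 4 is therefore expected to be small, a 1.3-fold higher number from compound 2 to compound 4 (0.10 log units; within the scatter), not beyond the usual scatter in either direction. Compound 4 is estimated at 100000 nM in this assay, within a range from 30000 nM to 300000 nM.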

Compound 4, half-maximal inhibitory concentration: > 200000 nM
Compound 4: a limit, no number; the forecaster's own chance of this, stated with the estimate: 30%; middle value at least 2.0-fold (0.30 log units) from the limit.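

The exchange of cyanosulfanyl for (methylsulfonyl)methyl on this aromatic carbon gives an at least 2.5-fold higher number from compound 2 to compound 4 (0.40 log units; beyond the scatter) in this assay. Going by these compounds alone, this is the first step in the set between compounds that differ in one place, and it shows that the read-out depends on the group held at this carbon, something compound 1 and compound 3 could not show. The value of compound 4 is a limit and not a number, and the full size of the step cannot be read because compound 4 stands at that limit: the limit of > 200000 nM in this assay, at which 2 of the 4 values shown sit.

The compounds shown leave open whether the higher number follows from the loss of cyanosulfanyl or from the arrival of (methylsulfonyl)methyl, as a single pair cannot separate the two. They also do not tell how an amine, a bromine atom or a longer alkyl chain on the same aromatic carbon would stand in this assay, or whether any group there would give stronger inhibition than compound 2 does.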